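The compounds below may be only part of what the source reports. "The series", "measured", "known", "first", "only" and "open" are said of these compounds alone.

Working notes on the series sharing the core of compound 1 (`Cc1cc(Nc2cc(N3CCN(C)CC3)nc(Nc3ccc(S(N)(=O)=O)cc3)n2)n[nH]1`), read in a functional assay on SK-BR-3 cells (Homo sapiens) for antiproliferative activity, read by CCK-8 assay, with a stated time of 72 h; on this read-out lower numbers stand for stronger inhibition and higher numbers for weaker inhibition. Here compound 1 gives 15900 nM, compound 2 (`Cc1cc(Nc2cc(N3CCN(C)CC3)nc(Nc3ccc(Cl)cc3)n2)n[nH]1`) gives 1610 nM, and compound 3 (`Cc1cc(Nc2cc(N3CCN(C)CC3)nc(Nc3cccc([N+](=O)[O-])c3)n2)n[nH]1`) gives 2180 nM. Compound 3 sits level with the 4-chlorophenyl member: the numbers show a 1.4-fold higher number from compound 2 to compound 3 (0.13 log units; within the scatter), so these two are not separated. Only the sulfamoyl member stands apart, with a 7.3-fold lower number from compound 1 to compound 3 (0.86 log units; beyond the scatter).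

The next entry is compound 4 (`Cc1cc(Nc2cc(N3CCN(C)CC3)nc(Nc3cccc(Cl)c3)n2)n[nH]1`), which has chloro in place of nitro on an aromatic carbon, meta to a large group: chloro in place of nitro on an aromatic carbon. Among the compounds with values here, no measured pair makes this exact exchange, so the evidence is indirect. Replacing sulfamoyl with chloro gave a 9.9-fold lower number from compound 1 to compound 2 (0.99 log units; beyond the scatter), a drop of similar size to the one already noted for the 3-nitrophenyl member. The exchange of 4-chlorophenyl for 3-nitrophenyl stayed within the scatter. As far as these compounds go, on these three compounds, no step beyond the scatter is expected in this assay, and the direction remains open. The expected step is a 1.2-fold lower number from compound 3 to compound 4 (0.08 log units; within the scatter). The estimate for compound 4 is 1800 nM, with an expected range from 800 nM to 4000 nM.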

Compound 4, half-maximal inhibitory concentration: 2290 nM
Compound 4: the middle estimate sits 1.3-fold (0.10 log units) below what was measured, and the stated range covers the measured number.
By their numbers in this assay, from the lowest: compounds 2, 3 and 4 (each within the scatter of the next); then compound 1.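

In this assay, chloro in place of nitro gives a 1.1-fold higher number from compound 3 to compound 4 (0.02 log units; within the scatter), so on this aromatic carbon, meta to a large group, the two groups are not separated, even though they differ in heavy atoms and hydrogen-bond acceptors. Within the data shown here, compound 4 also gives the first direct reading of where the chlorine sits: 3-chlorophenyl in place of 4-chlorophenyl gives a 1.4-fold higher number from compound 2 to compound 4 (0.15 log units; within the scatter), so these two placements are not separated either, while 3-chlorophenyl in place of 4-sulfamoylphenyl gives a 6.9-fold lower number from compound 1 to compound 4 (0.84 log units; beyond the scatter), leaving compound 1 as the only member apart from the rest. No measurement available here accounts for the level values of compounds 2, 3 and 4 or for the gap to compound 1.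

As far as these compounds go, it remains open whether the level values hold for other groups on this phenyl ring, such as an amine, a carboxylic acid or a methoxy group. From the compounds shown here alone, it also remains open whether the gap of compound 1 follows the sulfamoyl group itself or its placement, a question that 3-sulfamoylphenyl on the same nitrogen would address.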